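The compounds below may be only part of what the source reports. "The series", "measured", "known", "first", "only" and "open" are said of these compounds alone.

Compound 1, `Cc1ccc(NC(=O)Nc2ccccc2Cl)cc1NC(=O)c1ccccc1`; compound 2, `Cc1ccc(NC(=O)Nc2ccc(Cl)nc2)cc1NC(=O)c1ccccc1`; compound 3, `CC(=O)Nc1cc(NC(=O)c2cc(C)on2)ccc1C`.

In a functional assay on A375P cells (Homo sapiens) for antiproliferative activity (a lower number here means a stronger inhibitor, a higher number a weaker inhibitor), compound 1 reports only a limit, > 30000 nM. Compound 2 gives 1600 nM in this assay. Compound 3 likewise reaches only the limit of this assay, > 30000 nM, and so stands at the limit of > 30000 nM in this assay, at which 2 of the 3 values shown sit. Within the data shown here, the single measured step, an at least 18-fold lower number from compound 1 to compound 2 (1.27 log units; beyond the scatter), concerns another part of the shared core. Among the measured compounds shown here, compound 4, `Cc1cc(C(=O)Nc2ccc(C)c(NC(=O)c3ccccc3)c2)no1`, differs from compound 3 by phenyl in place of methyl on a carbonyl carbon, a change for which no measured step exists. Compound 2 carries the same benzoyl group and gives 1600 nM, yet it is not a one-step neighbour of compound 4. The step of an at least 2.0-fold lower number from compound 3 to compound 4 (0.30 log units; that floor lies within the scatter) is therefore expected only tentatively. Compound 4 is estimated at 15000 nM, between 3000 nM and 60000 nM.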

Compound 4, half-maximal inhibitory concentration: > 30000 nM
Compound 4 ended at the assay's limit (the forecaster's own chance of this, stated with the estimate: 45%); middle value at least 2.0-fold (0.30 log units) from the limit.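

In this assay, compound 4, with benzoyl in place of acetyl, still gives only a limit, > 30000 nM. The benzoyl group shared with compound 2 is thus not enough on its own for a measurable value: 5-methyl-1,2-oxazol-3-yl in place of (6-chloropyridin-3-yl)amino on a carbonyl carbon gives an at least 18-fold higher number from compound 2 to compound 4 (1.27 log units; beyond the scatter). The steps from compound 3 and from compound 1 to compound 4 cannot be read, and the limit now dominates the series: the limit of > 30000 nM in this assay, at which 3 of the 4 values shown sit.

From the compounds shown here alone, it remains open whether the change from acetyl to benzoyl has any effect on a compound that reads clear of the limit. Going by these compounds, it is also open whether an amine in place of the methyl on the 5-methyl-1,2-oxazol-3-yl group would give a measurable value.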